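A few compounds are considered here, and "the series" means these few. Any claim that something is new, unique, unknown or untested is made for them only; others in the source may bear on it.

Among the compounds with values here, compound 2 `O=C(c1ccc(F)c(O)c1)c1ccc2ccc(-c3nnn[nH]3)cc2n1` gives the lower of the two numbers measured so far: in an assay for inhibition of 17-beta-hydroxysteroid dehydrogenase type 2 (Homo sapiens), read by HPLC, with a stated time of 10 min, tested at 1 uM (a higher number here means more inhibition at the concentration tested (going by the name of the read-out), a lower number less inhibition), compound 2 gives 52%, while compound 1 `Nc1ccc2ccc(C(=O)c3ccc(F)c(O)c3)nc2c1` gives 83%. These two differ in one place, and the step of a number 31 percentage points lower from compound 1 to compound 2 (beyond the scatter) came with 1H-tetrazol-5-yl in place of amino on an aromatic carbon.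

Compound 3 `O=C(O)CNc1ccc2ccc(C(=O)c3ccc(F)c(O)c3)nc2c1` differs from compound 2 by (carboxymethyl)amino in place of 1H-tetrazol-5-yl on an aromatic carbon. Within the data shown here, the only measured step that bears on this change is the one from compound 1 to compound 2, which was large. The entering (carboxymethyl)amino contains an amino, as compound 1 does, so a partial return toward the value of compound 1 is expected rather than a full one, giving an expected upward step a number 14 percentage points higher from compound 2 to compound 3 (beyond the scatter) that goes beyond the scatter. Compound 3 is therefore estimated at 66%, with a range from 45% to 85%.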

Compound 3, a percentage reported as inhibition, at one concentration (the size of the read-out at that concentration, not a potency): 63%
Compound 3: middle estimate off by 3 percentage points, on the high side; the range from low to high includes it.
By their numbers in this assay, from the lowest: compound 2; then compound 3; then compound 1.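

In this assay, (carboxymethyl)amino in place of 1H-tetrazol-5-yl gives a number 11 percentage points higher from compound 2 to compound 3 (beyond the scatter). Both groups have 5 heavy atoms, so heavy-atom count alone does not set the number at this position. Carboxymethyl on the nitrogen of the amino group gives a number 20 percentage points lower from compound 1 to compound 3 (beyond the scatter), so a substituted nitrogen here keeps more inhibition than the tetrazole does, but the unsubstituted amino stays highest of the three. Nothing available explains either step.

These compounds do not separate the effect of the carboxylic acid end of the new chain from that of the chain itself. A plain methyl on the nitrogen, or a longer chain ending in a carboxylic acid, would help to pull those two apart.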